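The source may hold more compounds than are shown below. What is called first, only, known or untested is meant among the compounds shown, and "the series" means these compounds.

Measured in a physicochemical assay for inhibition, read by fluorescence, with a stated time of 2 min, in the presence of a further agent that is not named here; a lower number here means a stronger inhibitor, a higher number a weaker inhibitor:

Compound 1, `O=c1cc(/C=C/C=C/c2ccc(O)c(O)c2)oc2ccccc12`, gives 340 nM.
Compound 2, `O=c1cc(/C=C/C=C/c2ccc(O)c(O)c2)oc2cccc(O)c12`, gives 400 nM.

Compound 1 stands at the lowest of the two numbers in this assay, with compound 2 its nearest neighbour; the step of a 1.2-fold higher number from compound 1 to compound 2 (0.07 log units; within the scatter) is within the scatter, so the two compounds cannot be ordered against each other.

Compound 3, `O=c1cc(/C=C/C=C/c2ccc(O)c(O)c2)oc2cc(O)ccc12`, has not yet been measured. It differs from compound 1 by hydroxy in place of hydrogen on an aromatic carbon. Going by the values given here, the one measured step that bears on this change is the addition of a hydroxy group to the shared core in going from compound 1 to compound 2, which gave a 1.2-fold higher number from compound 1 to compound 2 (0.07 log units; within the scatter) and stayed within the scatter. That step concerns a hydroxy on a different carbon of the same core, so it is a guide rather than a copy of the change to compound 3.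

Among the compounds with values here, on that basis compound 3 is expected to show no step beyond the scatter, because the only comparable change gave a 1.2-fold higher number from compound 1 to compound 2 (0.07 log units; within the scatter). The estimate for compound 3 in this assay is 360 nM, in a range of 180 nM to 720 nM, which corresponds to an expected step of a 1.1-fold higher number from compound 1 to compound 3 (0.02 log units; within the scatter).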

Compound 3, half-maximal inhibitory concentration: 300 nM
For compound 3 the middle estimate is 1.2-fold (0.08 log units) above the measured one; the measured number falls inside the stated range.
By their numbers in this assay, from the lowest: compounds 3, 1 and 2 (each within the scatter of the next).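

In this assay, going by these compounds alone, hydroxy in place of hydrogen on this aromatic carbon, meta to a fused ring and para to a fused ring, gives a 1.1-fold lower number from compound 1 to compound 3 (0.05 log units; within the scatter) and so produces no step that can be told from repeated measurement. Compound 2 had shown this for only one carbon of the shared core, with a 1.2-fold higher number from compound 1 to compound 2 (0.07 log units; within the scatter) as its step, and compound 3 now extends the same result to a second carbon. Across these two positions, adding a hydroxy group therefore leaves the number in this assay unresolved from that of compound 1, with neither compound going against this, although the result says nothing about why, as nothing measured here bears on the cause.

The compounds shown leave open whether a group other than hydroxy on this carbon, such as a methoxy group, an amine or a carboxylic acid, would give a step beyond the scatter. They also leave open how far the number depends on the hydroxy groups that compound 1, compound 2 and compound 3 all share, since these stay the same throughout.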